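The compounds below may be only part of what the source reports. "The series", "measured", "known", "first", "only" and "open" are said of these compounds alone.

Compound 3 `CC(C)(C)CC(=O)Nc1cccc(C(=O)N2CCCC(C(=O)Nc3ccc(Cl)cc3)C2)c1` belongs to a small set built on one shared core, the amide with a 4-chlorophenyl group attached to a piperidine carboxamide. In an ADME assay on PC-3 cells (Homo sapiens) for cytotoxicity, read by WST assay, tested at 100 uM (a higher number here means more inhibition at the concentration tested (going by the name of the read-out), a lower number less inhibition), compound 3 gives 0%, level with compound 1 `Cc1cccc(C(=O)N2CCCC(C(=O)Nc3ccc(Cl)cc3)C2)c1`, which gives 0% in this assay; together these two stand lowest among the three measured numbers, and no change at the digits printed from compound 1 to compound 3 (within the scatter). Compound 2 `O=C(Nc1ccc(Cl)cc1)C1CCCN(C(=O)c2cccc(-c3nccs3)c2)C1` is the one that stands apart, giving 32% in this assay.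

Compound 4 `O=C(Nc1ccc(Cl)cc1)C1CCCN(C(=O)c2cccc(-c3cccs3)c2)C1` differs from compound 3 in one place: thiophen-2-yl in place of (neopentylcarbonyl)amino on an aromatic carbon

For the measured compounds named here, two measured steps bear on this change. In a number 32 percentage points higher from compound 1 to compound 2 (beyond the scatter) a five-membered aromatic ring entered in place of methyl, and in a number 32 percentage points lower from compound 2 to compound 3 (beyond the scatter) that same ring left in favour of the (neopentylcarbonyl)amino group. Thiophen-2-yl is again a five-membered aromatic ring with one hetero atom, so a rise of similar size is expected, estimated as a number 25 percentage points higher from compound 3 to compound 4 (beyond the scatter). Compound 4 is therefore expected to give about 25% in this assay, within a range from 0% to 50%.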

Compound 4, a percentage reported as inhibition, at one concentration (the size of the read-out at that concentration, not a potency): 4%
For compound 4 the middle estimate is 21 percentage points above the measured one; the range from low to high includes it.
By their numbers in this assay, from the lowest: compounds 1, 3 and 4 (each within the scatter of the next); then compound 2.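

Replacing 1,3-thiazol-2-yl with thiophen-2-yl, which is also a five-membered aromatic ring, gives a number 28 percentage points lower from compound 2 to compound 4 (beyond the scatter) in this assay, so a ring of this size at this place does not on its own go with the higher number. Set against the other two groups, thiophen-2-yl gives a number 4 percentage points higher from compound 3 to compound 4 (within the scatter) and a number 4 percentage points higher from compound 1 to compound 4 (within the scatter), so methyl, (neopentylcarbonyl)amino and thiophen-2-yl cannot be told apart at this place, and compound 2 alone stands apart among the four. Nothing measured here accounts for the gap between the two rings.

Going by these compounds, whether an oxazol-2-yl or a pyridin-2-yl ring at this place would side with compound 2 or with compound 4 remains open. Also open, on these data alone, is whether the gap between these two compounds would hold at other concentrations.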